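One more methoxy on compound 3

The source may hold more compounds than are shown below. What is called first, only, known or untested is meant among the compounds shown, and "the series" means these compounds.

Values in an ADME assay on MCF7 cells (Homo sapiens) for cytotoxicity, with a stated time of 72 h (a lower number here means a stronger inhibitor, a higher number a weaker inhibitor), for the measured compounds
compound 1 `COc1ccccc1CNc1ncnc2c1ncn2C1CCCCO1` gives > 100000 nM as a limit
compound 2 `COc1cccc(CNc2ncnc3c2ncn3C2CCCCO2)c1` gives 97000 nM
compound 3 `COc1ccc(OC)c(CNc2ncnc3c2ncn3C2CCCCO2)c1` gives 25400 nM

The entry for compound 1 is a limit of the assay and not a number. Compound 3 at 25400 nM stands lowest of the three compounds.

Compound 4 `COc1cc(OC)c(OC)cc1CNc1ncnc2c1ncn2C1CCCCO1` differs from compound 3 by one change methoxy in place of hydrogen on an aromatic carbon and this is methoxy in place of hydrogen on an aromatic carbon, ortho to a methoxy group, meta to a methoxy group and para to a large group.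

The same kind of change gave a 3.8-fold lower number from compound 2 to compound 3 (0.58 log units; beyond the scatter) and also an at least 3.9-fold lower number from compound 1 to compound 3 (0.59 log units; beyond the scatter) in the earlier series. Moving the single methoxy gave an at least 1.0-fold lower number from compound 1 to compound 2 (0.01 log units; that floor lies within the scatter) and adds little. Both steps starting from compound 1 rest on the limit of > 100000 nM in this assay, at which 1 of the 3 values shown sits, and are bounds only.

From a 3.8-fold lower number from compound 2 to compound 3 (0.58 log units; beyond the scatter) a modest lowering is expected in this assay for the new change. The estimated 1.8-fold lower number from compound 3 to compound 4 (0.26 log units; within the scatter) would be a modest one. Compound 4 is estimated at 14000 nM with an expected range from 4000 nM to 45000 nM in this assay.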

Compound 4, half-maximal inhibitory concentration: > 100000 nM
Compound 4: only a limit was reported (the forecaster's own chance of this, stated with the estimate: 3%); middle value at least 7.1-fold (0.85 log units) away from the limit.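

In this assay, a further methoxy group on the aromatic carbon ortho to a methoxy group, meta to a methoxy group and para to a large group gives an at least 3.9-fold higher number from compound 3 to compound 4 (0.59 log units; beyond the scatter), while the same kind of change in compound 3's earlier series gave a 3.8-fold lower number from compound 2 to compound 3 (0.58 log units; beyond the scatter). This change therefore has no single direction across these compounds, and where the methoxy enters the ring matters as much as its presence. Compound 4 gives > 100000 nM, which is a limit of the assay and not a number, so the step has a floor only: the limit of > 100000 nM in this assay, at which 2 of the 4 values shown sit.

The compounds shown leave open whether the rise belongs to this position alone or to the three methoxy groups taken together. They also leave open how a hydroxy group, an amine or a longer chain such as ethoxy would behave at this same position.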